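Swapping an Amide for a Sulfone on the Shared Core

A few compounds are considered here, and "the series" means these few. Any claim that something is new, unique, unknown or untested is made for them only; others in the source may bear on it.

Of the compounds shown here, three built on one shared core have been measured in a functional assay for inhibition of Thromboxane-A synthase (Homo sapiens); on this read-out higher numbers stand for weaker inhibition and lower numbers for stronger inhibition. Compound 1 `CCCCCCCCOC(=O)c1ccc(COC(COCc2ccc(OC)cc2)Cn2ccnc2)cc1` gives 21000 nM, compound 2 `COc1ccc(COCC(Cn2ccnc2)OCc2ccc(C(=O)O)cc2)cc1` gives 6700 nM, and compound 3 `COc1ccc(COCC(Cn2ccnc2)OCc2ccc(C(=O)N(C)C)cc2)cc1` gives 1940 nM. Compound 3 therefore stands at the lowest number of the three, the strongest inhibitor among them: the step of a 3.5-fold lower number from compound 2 to compound 3 (0.54 log units; beyond the scatter) and the step of an 11-fold lower number from compound 1 to compound 3 (1.03 log units; beyond the scatter) both lie beyond the scatter. The step of a 3.1-fold lower number from compound 1 to compound 2 (0.50 log units; beyond the scatter) shows that the earlier change at the same place on the ring was also felt.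

Compound 4 `COc1ccc(COCC(Cn2ccnc2)OCc2ccc(S(C)(=O)=O)cc2)cc1` has not yet been measured. It differs from compound 3 in one place: methylsulfonyl in place of dimethylcarbamoyl on an aromatic carbon. Going by the values given here, none of the measured steps exchanges these two groups, so no step bears on it directly. What the measured steps do show is that every change at this position moved the number, the step of an 11-fold lower number from compound 1 to compound 3 (1.03 log units; beyond the scatter) being the largest. A shift of modest size is therefore expected, in either direction, with a weaker outcome somewhat more likely. Compound 4 is estimated at 3000 nM, with a range from 1000 nM to 9000 nM. This estimate means an expected step of a 1.5-fold higher number from compound 3 to compound 4 (0.19 log units; within the scatter).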

Compound 4, half-maximal inhibitory concentration: 24900 nM
Estimate against measurement, compound 4: 8.3-fold (0.92 log units) below; measured number above the stated range.
By their numbers in this assay, from the lowest: compound 3; then compound 2; then compounds 1 and 4 (each within the scatter of the next).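

In this assay methylsulfonyl proves no substitute for dimethylcarbamoyl at this place on the ring, since the exchange gives a 13-fold higher number from compound 3 to compound 4 (1.11 log units; beyond the scatter) and so undoes the gain that compound 3 held over the other two compounds. Methylsulfonyl also falls behind the free carboxy group, with a 3.7-fold higher number from compound 2 to compound 4 (0.57 log units; beyond the scatter) as the result, whereas the comparison with octyloxycarbonyl gives a 1.2-fold higher number from compound 1 to compound 4 (0.07 log units; within the scatter) and leaves those two compounds impossible to tell apart. So a group as long as the octyl ester and the much shorter methylsulfonyl group end up level here, which means the size of the group alone does not order these four compounds, and compound 3 remains the strongest inhibitor among them.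

From the compounds shown here alone, whether this advantage belongs to dimethylcarbamoyl alone, or extends to a plain unsubstituted amide, an amide with longer chains on its nitrogen, a nitrile or a simple amine, stays open. Nothing available here explains why the amide and the methylsulfonyl compound differ so widely.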